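Cyano for Methoxy on the Piperidine Aryl Ring

A few compounds are considered here, and "the series" means these few. Any claim that something is new, unique, unknown or untested is made for them only; others in the source may bear on it.

The series is followed in a functional assay on HEK293 cells for agonist activity at D(4) dopamine receptor (Homo sapiens), read by FLIPR; on this read-out lower numbers stand for an effect already at smaller amounts and higher numbers for an effect only at larger amounts of compound. Compound 1 `COc1ccccc1C1CCN(CC(=O)Nc2cccc(C)c2)CC1` gives 420 nM, the highest of the three numbers recorded; compound 2 `O=C(CN1CCC(c2cccc[n+]2[O-])CC1)NC1CCCCC1` gives 294 nM, a value within the scatter of compound 1, while compound 3 `Cc1cc(F)ccc1NC(=O)CN1CCC(c2cccc[n+]2[O-])CC1` gives 60 nM, which lies beyond the scatter below compound 1. Within the data shown here, the only single-site step measured so far is a 4.9-fold lower number from compound 2 to compound 3 (0.69 log units; beyond the scatter), and it concerns the group on the amide nitrogen, not the aryl ring on the piperidine.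

Compound 4 `Cc1cccc(NC(=O)CN2CCC(c3ccccc3C#N)CC2)c1` differs from compound 1 at that aryl ring: cyano in place of methoxy on an aromatic carbon. Among the measured compounds shown here, no measured step touches this position, so the data give no direction for the change. Compound 4 is therefore expected to sit close to compound 1, with a step of a 1.1-fold lower number from compound 1 to compound 4 (0.02 log units; within the scatter) in this assay that is not expected to exceed the scatter. The estimate for compound 4 is 400 nM, with a range from 120 nM to 1400 nM reflecting the lack of guiding data.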

Compound 4, half-maximal effective concentration: 8 nM
Compound 4: the middle estimate sits 50-fold (1.70 log units) above what was measured, and the stated range ends above it.
By their numbers in this assay, from the lowest: compound 4; then compound 3; then compounds 2 and 1 (each within the scatter of the next).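

Among these compounds, the position on the aryl ring, which no earlier step had touched, proves highly sensitive in this assay: going from 2-methoxyphenyl to 2-cyanophenyl gives a 53-fold lower number from compound 1 to compound 4 (1.72 log units; beyond the scatter). The two groups have the same count of heavy atoms and of hydrogen-bond acceptors and carry no net charge, so a change that leaves these counts as they were can still move the number a long way at this place, ortho to a large group. No evidence is available on what lies behind the step.

The compounds shown leave open how other groups at this place, such as an amine, a carboxylic acid or trifluoromethyl, would compare with cyano. Also open, from the compounds shown here alone, is whether cyano in place of methoxy would give a similar step with cyclohexyl or 4-fluoro-2-methylphenyl on the amide nitrogen.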